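The source may report more compounds than this note shows. Statements on the series, on what has been measured and on what is new or still open speak of the compounds shown alone.

In an in vitro functional assay on B300-19 cells for antagonist activity at C-C chemokine receptor type 4 (Homo sapiens), read by GTPgammaS binding, tested at 1 uM (a lower number here means less inhibition, a higher number more inhibition at the concentration tested (going by the name of the read-out)), the measured compounds read as follows:
compound 1 `COc1cc2nc(NCCN3CCCCC3)nc(NC3CCCCCC3)c2cc1OC` gives 1%.
compound 2 `COc1cc2nc(NCc3ccccc3)nc(NC3CCCCCC3)c2cc1OC` gives 13%.
compound 3 `COc1cc2nc(NC(C)C)nc(NC3CCCCCC3)c2cc1OC` gives < 0%, which is a limit of the assay rather than a number.

Compound 3 thus sits at the floor of this assay (the limit of < 0% in this assay, at which 1 of the 3 values shown sits), with no numerical value of its own. Compound 4 `COc1cc2nc(N3CCC(C(N)=O)CC3)nc(NC3CCCCCC3)c2cc1OC` is its partner here, and the change is 4-carbamoylpiperidin-1-yl in place of isopropylamino on an aromatic carbon. Two measured steps end at this same position: a number at least 1 percentage points lower from compound 1 to compound 3 (that floor lies within the scatter) and a number at least 13 percentage points lower from compound 2 to compound 3 (beyond the scatter). Read in reverse, replacing isopropylamino at this carbon gave either nothing beyond the scatter or a modest rise, never a fall. For compound 4 a small rise is therefore expected, a number at least 6 percentage points higher from compound 3 to compound 4 (that floor lies within the scatter). Compound 4 is estimated at 6%, with a range from -5% to 20%.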

Compound 4, a percentage reported as inhibition, at one concentration (the size of the read-out at that concentration, not a potency): 17%
Estimate against measurement, compound 4: 11 percentage points below; the range from low to high includes it.
By their numbers in this assay, from the lowest: compound 1; then compounds 2 and 4 (each within the scatter of the next). At a limit, below all of these: compound 3.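

Going by these compounds alone, compound 4 puts a ring directly on the aromatic carbon between two ring nitrogen atoms, where the earlier compounds carry amino groups, and this still gives measurable inhibition: replacing isopropylamino gives a number at least 17 percentage points higher from compound 3 to compound 4 (beyond the scatter), and replacing (2-(piperidin-1-yl)ethyl)amino gives a number 16 percentage points higher from compound 1 to compound 4 (beyond the scatter). Replacing benzylamino gives a number 4 percentage points higher from compound 2 to compound 4 (within the scatter), so the phenyl ring of compound 2 is not needed for this level of inhibition. The step from compound 3 starts from a limit rather than a number: the limit of < 0% in this assay, at which 1 of the 4 values shown sits.

Going by these compounds, what a carboxylic acid or a primary amine in place of the carbamoyl group would give stays open. So does the effect of compound 4 at any other concentration, as only one concentration is reported.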